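Halogenated benzyl in place of 2-cyanobenzyl on a piperidinol core

The source may report more compounds than this note shows. Statements on the series, on what has been measured and on what is new or still open speak of the compounds shown alone.

Compound 2 `N#Cc1ccccc1CN1CCC(O)(Cn2cnc3c(cnn3-c3ccc(F)cc3)c2=O)CC1` sits at the weaker end of the two numbers shown: in an assay on Sf21 cells for inhibition of ubiquitin carboxyl-terminal hydrolase 7 (Homo sapiens), read by spectrophotometry, with stated times of 30 min and 2 h (on this read-out higher numbers stand for weaker inhibition and lower numbers for stronger inhibition), compound 2 gives 8100 nM, while compound 1 `COC(=O)c1ccc(N2CCC(O)(Cn3cnc4c(Br)n(C)nc4c3=O)CC2)c(Cl)c1` gives 157 nM in this assay, a gap well beyond the scatter. Compound 3 `O=c1c2cnn(-c3ccc(F)cc3)c2ncn1CC1(O)CCN(Cc2ccc(Br)cc2Cl)CC1` is unmeasured and differs from compound 2 in one place: 4-bromo-2-chlorophenyl in place of 2-cyanophenyl on a saturated chain carbon bound to an amine nitrogen in a ring. For the measured compounds named here, with no measured pair sharing this change, only a modest step is expected, toward stronger inhibition, as a 2.7-fold lower number from compound 2 to compound 3 (0.43 log units; beyond the scatter). On that basis compound 3 is estimated at 3000 nM in this assay, with a range from 800 nM to 12000 nM.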

Compound 3, half-maximal inhibitory concentration: 1900 nM
Estimate against measurement, compound 3: 1.6-fold (0.20 log units) above; the measured number falls inside the stated range.
By their numbers in this assay, from the lowest: compound 1; then compound 3; then compound 2.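

On the saturated chain carbon bound to an amine nitrogen in a ring, the aryl group turns out to affect inhibition: in this assay, 4-bromo-2-chlorophenyl in place of 2-cyanophenyl gives a 4.3-fold lower number from compound 2 to compound 3 (0.63 log units; beyond the scatter). This first one-place comparison shows that the nitrile is not required for inhibition in this series, as compound 3 lacks it and still gives the lower number. Nothing measured here accounts for the step. Going by these compounds, compound 3 brings in bromine and chlorine together, so the share of each remains open. Also open, on these data alone, is how an unsubstituted phenyl, or a phenyl carrying an amine or a carboxylic acid, would behave at this position.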